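The compounds below may be only part of what the source reports. "The series", "measured", "known", "first", "only" and "open" are said of these compounds alone.

In a functional assay on PC-3 cells (Homo sapiens) for inhibition, read by sulforhodamine B assay, with a stated time of 48 h, tested at 50 uM (a lower number here means less inhibition of growth, a higher number more inhibition of growth at the concentration tested), compound 1 (`COc1cc2c(cc1CC=C(C)C)C(=O)C[C@@H](c1ccc(Oc3cccc([N+](=O)[O-])c3)cc1)O2`) gives 21% and stands lowest of the three measured numbers. Compound 2 (`COc1ccc([C@@H]2C/C(=N/OCc3cn(-c4cccc(CO)c4)nn3)c3cc(CC=C(C)C)c(OC)cc3O2)cc1`) gives 34% and compound 3 (`COc1cc2c(cc1CC=C(C)C)/C(=N/O)C[C@@H](c1ccc(O)cc1)O2`) gives 81% in the same read-out, both beyond the scatter from compound 1. Compound 4 (`C#CCOc1ccc([C@@H]2CC(=O)c3cc(CC=C(C)C)c(OC)cc3O2)cc1`) is still unmeasured. It carries propargyl in place of 3-nitrophenyl on an oxygen on an aromatic ring. Among the measured compounds shown here, no measured pair isolates this change, so any expectation is loose. For the measured compounds named here, compound 1 (21%) is the only measured compound sharing the carbonyl of compound 4 and sits at the low end. A modest rise is expected (a number 14 percentage points higher from compound 1 to compound 4 (beyond the scatter)) as an estimate, possibly close to the scatter. For compound 4 the estimated value is 35% (expected range 15% to 60%).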

Compound 4, percent growth inhibition at one concentration: 52%
The estimate for compound 4 lay 17 percentage points below the measured number; measured number inside the range.
By their numbers in this assay, from the lowest: compound 1; then compound 2; then compound 4; then compound 3.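

In this assay, the oxygen on the aromatic ring now has a single change that can be read: propargyl in place of 3-nitrophenyl gives a number 31 percentage points higher from compound 1 to compound 4 (beyond the scatter), with the rest of the core of compound 1 unchanged. At this position, propargyl with 3 heavy atoms therefore goes with more inhibition of growth than 3-nitrophenyl with 9. Nothing at hand explains this step. From the compounds shown here alone, it remains open whether the step follows the loss of the nitro group or of the whole aromatic ring. Plain phenyl or a longer alkyne chain such as butynyl on the same oxygen would bear on this.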